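The compounds below may be only part of what the source reports. "The series", "measured", "known", "first", "only" and "open" are said of these compounds alone.

Compound 1 `CC1CCN(C2CCN(S(=O)(=O)c3cccc(Br)c3)CC2)CC1` is the starting point. In a functional assay on DLD-1 cells (Homo sapiens) for antiproliferative activity, read by CellTiter-Glo, with a stated time of 72 h (a lower number here means a stronger inhibitor, a higher number a weaker inhibitor), compound 1 gives 3.2 nM, which is the higher of the two plain numbers in this set. Its nearest neighbour is compound 2 `COc1ccc(Br)cc1S(=O)(=O)N1CCC(N2CCC(C)CC2)CC1`, which in this assay gives 2 nM; the step of a 1.6-fold lower number from compound 1 to compound 2 (0.20 log units; within the scatter) is the change from methoxy in place of hydrogen on an aromatic carbon. Compound 3 `CC1CCN(C2CCN(S(=O)(=O)c3cccc(C(F)(F)F)c3)CC2)CC1` gives in this assay only the limit > 5000 nM. That step, an at least 1500-fold higher number from compound 1 to compound 3 (3.19 log units; beyond the scatter), comes from trifluoromethyl in place of bromo on an aromatic carbon, and it is one of the values that sit at the limit of > 5000 nM in this assay, at which 1 of the 3 values shown sits.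

Compound 4 `CC1CCN(C2CCN(S(=O)(=O)c3ccc(Cl)cc3Cl)CC2)CC1` has not yet been measured. It differs from compound 1 by 2,4-dichlorophenyl in place of 3-bromophenyl on a sulfonyl sulfur. Among the compounds with values here, no measured step swaps the whole aryl group in this way, but the step from compound 1 to compound 3 shows that altering the substituent on this ring can remove measurable activity entirely, so a loss of some size is expected, with wide uncertainty. For compound 4 the expected result in this assay is 300 nM, spanning 15 nM to 5000 nM, which corresponds to an expected step of a 94-fold higher number from compound 1 to compound 4 (1.97 log units; beyond the scatter).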

Compound 4, half-maximal inhibitory concentration: 1 nM
For compound 4 the middle estimate is 300-fold (2.48 log units) above the measured one; the measured number lies below the stated range.
By their numbers in this assay, from the lowest: compounds 4, 2 and 1 (each within the scatter of the next, the first and the last beyond it). At a limit, above all of these: compound 3.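

Swapping 3-bromophenyl for 2,4-dichlorophenyl on the sulfonyl sulfur gives a 3.2-fold lower number from compound 1 to compound 4 (0.51 log units; beyond the scatter), so in this assay strong activity at this place does not require a bromo group, and a different substitution of the ring can even lower the number somewhat. Compound 3 stands apart with a value that is a limit, > 5000 nM, so the loss seen with trifluoromethyl is not a general result of changing this aryl group. None of the information available explains why 2,4-dichlorophenyl is tolerated here while trifluoromethyl is not.

Compound 4 changes both the kind of substituent and the substitution of the ring at once, and the compounds shown cannot separate these two changes. They also leave open how a phenyl with a single chloro, or one carrying an amine or a carboxylic acid, would behave.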